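Taking the phenoxy group off compound 2

This account rests on a few compounds, and the source may have more. Where it says the series, first, only, none or still open, it means among the compounds named here.

Going by the values given here, in an ADME assay on BHK-21 cells (Mesocricetus auratus) for cytotoxicity, read by MTT assay, with a stated time of 72 h (a lower number here means that less compound is tolerated, a higher number that more compound is tolerated), compound 2 `Cc1ccccc1C1CC(c2ccc(Oc3ccccc3)cc2)=NN1c1ccc(S(N)(=O)=O)cc1` gives 7000 nM, the lower of the two numbers measured so far, and compound 1 `Cc1ccccc1C1CC(c2ccc(OCc3ccccc3)cc2)=NN1c1ccc(S(N)(=O)=O)cc1` gives 20000 nM. The next compound to be tested is compound 3 `Cc1ccccc1C1CC(c2ccccc2)=NN1c1ccc(S(N)(=O)=O)cc1`, and the change is hydrogen in place of phenoxy on an aromatic carbon, with hydrogen in place of phenoxy on an aromatic carbon. Among the compounds with values here, only one measured step bears on this, and only indirectly: a 2.9-fold lower number from compound 1 to compound 2 (0.46 log units; beyond the scatter), a modest step beyond the scatter that put phenyl in place of benzyl on the oxygen and removed no group outright. Within the data shown here, no measured compound lacks the group, so the direction is a judgement rather than a reading of the data. A modest move to a higher number is expected, and the estimated step is a 2.6-fold higher number from compound 2 to compound 3 (0.41 log units; beyond the scatter). The estimate for compound 3 is 18000 nM, with an expected range of 6000 nM to 50000 nM.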

Compound 3, half-maximal cytotoxic concentration: 14000 nM
The estimate for compound 3 lay 1.3-fold (0.11 log units) above the measured number, and the stated range covers the measured number.
By their numbers in this assay, from the lowest: compounds 2, 3 and 1 (each within the scatter of the next, the first and the last beyond it).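

Going by these compounds alone, compound 3 gives the first reading of this aromatic carbon, para to a large group, with no ether substituent on it. In this assay taking off phenoxy gives a 2.0-fold higher number from compound 2 to compound 3 (0.30 log units; within the scatter) and taking off benzyloxy gives a 1.4-fold lower number from compound 1 to compound 3 (0.15 log units; within the scatter) in the same assay. Neither removal, although each takes away a whole six-membered aromatic ring of carbon only, produces a step beyond the scatter, so of the three compounds only compound 1 and compound 2 stand apart by more than the scatter. Nothing available here bears on why these numbers fall as they do.

From the compounds shown here alone, whether an amine, a carboxylic acid or a small methoxy group on this carbon would stay within the scatter of compound 3 remains open. The shared core is the same in all three compounds, so these results say nothing about changes elsewhere on it.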